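A few compounds are considered here, and "the series" means these few. Any claim that something is new, unique, unknown or untested is made for them only; others in the source may bear on it.

In a functional assay on L1210 cells (Mus musculus) for inhibition (a lower number here means a stronger inhibitor, a higher number a weaker inhibitor), three compounds have been measured so far:

compound 1, `O=C1/C(=C/c2cccc(Cl)c2)CCCc2ccccc21`, gives 52300 nM;
compound 2, `O=C1/C(=C/c2cccc(Br)c2)CCCc2ccccc21`, gives 51000 nM;
compound 3, `O=C1CCCCC/C1=C\c1ccc(Cl)cc1`, gives 83000 nM.

Compound 4, `O=C1CCCCC/C1=C\c1ccc(Br)cc1`, awaits measurement in this assay.

Compound 1 and compound 2 share one core and differ in a single place: bromo in place of chloro on an aromatic carbon. The step of a 1.0-fold lower number from compound 1 to compound 2 (0.01 log units; within the scatter) left the number essentially unchanged. Compound 3 rests on a different core; the difference between the two cores is not broken down here. Its value stands within the scatter of both compound 1 and compound 2, so the three are not separated by these measurements.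

Compound 4 arises from compound 3 by bromo in place of chloro on an aromatic carbon. This is the same kind of change as that made between compound 1 and compound 2, but the surroundings differ: in compound 1 the change sits meta to a large group, whereas in compound 3 it sits para to a group of 9 heavy atoms. Resting on a 1.0-fold lower number from compound 1 to compound 2 (0.01 log units; within the scatter), the step of a 1.0-fold lower number from compound 3 to compound 4 (0.02 log units; within the scatter) is expected to be small. For compound 4 a value near 80000 nM is therefore estimated, most likely between 45000 nM and 140000 nM.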

Compound 4, half-maximal inhibitory concentration: 68400 nM
Compound 4: middle estimate off by 1.2-fold (0.07 log units), on the high side; the range from low to high includes it.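

Putting bromo in place of chloro on the second core gives a 1.2-fold lower number from compound 3 to compound 4 (0.08 log units; within the scatter) in this assay, so here too the swap leaves no readable mark on the number. Set beside the earlier step, the change looks the same on both cores, with no difference that can be told apart from the ordinary spread of repeated measurements: the same change on two cores in this assay, a 1.0-fold lower number (0.01 log units; within the scatter) from compound 1 to compound 2 and a 1.2-fold lower number (0.08 log units; within the scatter) from compound 3 to compound 4, 1.2-fold (0.07 log units) apart, within the scatter of two such steps

Going by these compounds alone, this supports carrying the chloro-to-bromo swap from one core to the other in this small series, but it rests on only two pairs, both of which show no measurable effect, so it does not show that a swap with a real effect would carry over in the same way, or that a third core would behave alike.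

The compounds shown carry only chloro or bromo on the aromatic ring, so how an amine, a carboxylic acid or a longer chain at that place would read in this assay remains open. Also open, from the compounds shown here alone, is what a plain hydrogen there would give on either core.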